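A few compounds are considered here, and "the series" means these few. Any claim that something is new, unique, unknown or untested is made for them only; others in the source may bear on it.

Compound 2, `CCCCCCCCc1cn([C@H]2C[C@@H]3OP(=O)(O)OC[C@H]3O2)c(=O)[nH]c1=O`, is measured in a functional assay on L1210 cells (Mus musculus) (on this read-out lower numbers stand for stronger inhibition and higher numbers for weaker inhibition), where compound 2 gives 193 ug/mL. Of the two plain numbers in this assay, that of compound 2 is the higher one; compound 1, `CCCCCCCCc1cn([C@H]2C[C@H](O)[C@@H](CO)O2)c(=O)[nH]c1=O`, gives 72 ug/mL. Compound 3, `CCCCc1cn([C@H]2C[C@H](O)[C@@H](CO)O2)c(=O)[nH]c1=O`, reaches only a limit of > 500 ug/mL in this assay, so its number is not known. The unmeasured compound 4, `CC(C)c1cn([C@H]2C[C@@H]3OP(=O)(O)OC[C@H]3O2)c(=O)[nH]c1=O`, differs from compound 2 in one place: isopropyl in place of octyl on an aromatic carbon. Among the compounds with values here, the single measured step that bears on this change is the shortening of the chain on the shared core, an at least 6.9-fold higher number from compound 1 to compound 3 (0.84 log units; beyond the scatter), a step whose full size stays hidden because the limit of > 500 ug/mL in this assay, at which 1 of the 3 values shown sits, caps the value of compound 3. Compound 4 carries an even shorter group than compound 3, with three carbon atoms where compound 3 has four, and its sugar part matches that of compound 2. On that basis the expected step is in the same direction as the measured one, towards weaker inhibition, and at least as large: a 4.7-fold higher number from compound 2 to compound 4 (0.67 log units; beyond the scatter). Compound 4 is therefore estimated in this assay at 900 ug/mL, within 300 ug/mL to 3000 ug/mL, with a good chance that the assay reports only a limit for compound 4.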

Compound 4, concentration for 50% inhibition: > 500 ug/mL
Compound 4 ended at the assay's limit; the forecaster's own chance of this, stated with the estimate: 75%; the middle value is on the limit's open side.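

In this assay compound 4 gives > 500 ug/mL, which is a limit of the assay and not a number. Replacing octyl with isopropyl on this aromatic carbon gives an at least 2.5-fold higher number from compound 2 to compound 4 (0.41 log units; beyond the scatter), so the loss that the earlier compounds showed on shortening the chain on the core of compound 1 now also appears on the core of compound 2, and the long chain at this position matters on both cores shown. The true size of the new step stays hidden, and it cannot be set against the earlier chain step in size, as each of the two steps ends at the same ceiling: the limit of > 500 ug/mL in this assay, at which 2 of the 4 values shown sit.

The compounds shown leave open at what chain length between isopropyl and octyl the number on the core of compound 2 starts to drop, and whether a branched group behaves differently from a straight propyl or butyl chain at this position. They also leave open whether a longer chain such as dodecyl, or an amine or a carboxylic acid carried on the octyl chain, would shift the number of compound 2 in either direction.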